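The source may hold more compounds than are shown below. What is called first, only, known or untested is meant among the compounds shown, and "the series" means these compounds.

Compound 1 `COc1cc(Nc2nc(C(=N)Nc3ccc(N4CCN(C)CC4)cc3)cc3c(-c4ccccc4)n[nH]c23)cc(OC)c1OC` is a trimethoxyanilino-substituted member of the series. In a functional assay on MDA-MB-231 cells (Homo sapiens) for cytotoxicity, read by MTT assay, with a stated time of 72 h (on this read-out higher numbers stand for weaker inhibition and lower numbers for stronger inhibition), compound 1 gives 4600 nM, which places it second highest among the three numbers recorded. Within the data shown here, its nearest neighbour is compound 3 `COc1cc(Nc2nc(C(=N)Nc3ccccc3)cc3c(-c4ccccc4)n[nH]c23)cc(OC)c1OC`, which in this assay gives 4500 nM; the step of a 1.0-fold lower number from compound 1 to compound 3 (0.01 log units; within the scatter) is the only single-point comparison available. The furthest is compound 2 `CN1CCN(c2ccc(NC(=N)c3cc4cn[nH]c4cn3)cc2)CC1`, a smaller compound lacking the phenyl and anilino substituents of the shared core, which in this assay gives 47500 nM; the two values for compound 1 and compound 2 differ well beyond the scatter.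

Compound 4 `COc1ccc(Cn2nc(-c3ccccc3)c3cc(C(=N)Nc4ccc(N5CCN(C)CC5)cc4)nc(Nc4cc(OC)c(OC)c(OC)c4)c32)cc1` differs from compound 1 by 4-methoxybenzyl in place of hydrogen on an aromatic nitrogen. Among the measured compounds shown here, no measured pair in the set touches this ring nitrogen; the one step on record, from compound 1 to compound 3, concerns the aromatic carbon of the anilino ring and was within the scatter. For the measured compounds named here, there is therefore no measured precedent for the substitution in compound 4, and the expectation rests on the unchanged core alone. The step from compound 1 to compound 4 is expected to be a 1.1-fold higher number from compound 1 to compound 4 (0.04 log units; within the scatter), that is, none beyond the scatter. Compound 4 is accordingly estimated at 5000 nM in this assay, with a range from 1500 nM to 20000 nM.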

Compound 4, half-maximal inhibitory concentration: 890 nM
Compound 4: the middle estimate sits 5.6-fold (0.75 log units) above what was measured; measured number below the stated range.
By their numbers in this assay, from the lowest: compound 4; then compounds 3 and 1 (each within the scatter of the next); then compound 2.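

Placing 4-methoxybenzyl in place of hydrogen on the aromatic nitrogen gives a 5.2-fold lower number from compound 1 to compound 4 (0.71 log units; beyond the scatter) in this assay. The only earlier one-place change, a 1.0-fold lower number from compound 1 to compound 3 (0.01 log units; within the scatter), swapped hydrogen for 4-methylpiperazin-1-yl on an aromatic carbon and stayed within the scatter, so this nitrogen is the first position in the series shown to move the number beyond it, and it accepts a substituent bearing a six-membered aromatic ring of carbon only without any loss in this assay. No measurement in hand bears on why the number falls.

As far as these compounds go, it remains open which part of the 4-methoxybenzyl group carries the step, or whether replacing the hydrogen is enough: a methyl, an unsubstituted benzyl or a longer chain ending in an amine on the same nitrogen would separate these readings. From the compounds shown here alone, it is also open whether the step persists when hydrogen stands in place of 4-methylpiperazin-1-yl, as in compound 3, since one pair at this nitrogen cannot show whether the two changes act independently.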